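Methyl in place of amino: a series sitting at the limit

This account rests on a few compounds, and the source may have more. Where it says the series, first, only, none or still open, it means among the compounds named here.

Compound 1 `Cc1ccc2oc(CSc3nnc(C)s3)cc(=O)c2c1`, compound 2 `Cc1ccc2oc(CSc3nnc(N)s3)cc(=O)c2c1` and compound 3 `Nc1nnc(SCc2coc3ccccc3c2=O)s1` have each been run in a functional assay on SW480 cells (Homo sapiens) for cytotoxicity, read by MTT assay, with a stated time of 72 h; a higher number here means a weaker inhibitor, a lower number a stronger inhibitor. In this assay compound 1 gives > 25000 nM, which is a limit of the assay and not a number. Compound 2 gives > 25000 nM, again a limit. Compound 3 gives > 25000 nM, also a limit. All three values sit at the same limit, (the limit of > 25000 nM in this assay, at which 3 of the 3 values shown sit), so no order among them can be read.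

The change from compound 2 to compound 1 is methyl in place of amino on an aromatic carbon. Its step, a step that the two limits leave unreadable from compound 2 to compound 1, has no readable size: both ends are limits. Compound 3 and compound 2 differ in more than one place; the difference between the two cores is not broken down here.

Compound 4 `Cc1nnc(SCc2coc3ccccc3c2=O)s1` is not yet measured. It relates to compound 3 by methyl in place of amino on an aromatic carbon, the same change as from compound 2 to compound 1, at a place described in the same words.

The expectation for compound 4 rests on compound 3 giving only a limit, > 25000 nM. It rests further on the pair of compound 2 and compound 1, where the same change left both values at the limit, a step that the two limits leave unreadable from compound 2 to compound 1. Compound 4 is therefore expected to stay near the limit, with an estimated value of 40000 nM, between 15000 nM and 150000 nM. The expected step is a step that the limit leaves unreadable from compound 3 to compound 4, an estimate only.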

Compound 4, half-maximal inhibitory concentration: 1000 nM
Compound 4: the middle estimate sits 40-fold (1.60 log units) above what was measured; measured number outside the range, below it.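

In this assay, methyl in place of amino on an aromatic carbon gives an at least 25-fold lower number from compound 3 to compound 4 (1.39 log units; beyond the scatter), a large step on this core and the only readable measure of the change in the series. The same change on the other core, from compound 2 to compound 1, cannot be read, and the pair neither confirms nor contradicts the new step, with both ends standing at one limit: the limit of > 25000 nM in this assay, at which 3 of the 4 values shown sit. Carrying the same 5-methyl-1,3,4-thiadiazol-2-yl group as compound 4, compound 1 gives > 25000 nM, a limit of the assay and not a number, so this group does not give a readable value on every core, and the size of the step on one core cannot be carried over to the other.

Open, from the compounds shown here alone, is whether the step is specific to methyl or would also appear with another group in its place on the five-membered ring, such as ethyl, a longer chain or a carboxylic acid. Also open is which of the differences between the two cores decides whether a readable value appears, as the compounds shown do not separate these differences one at a time.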